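A few compounds are considered here, and "the series" means these few. Any claim that something is new, unique, unknown or untested is made for them only; others in the source may bear on it.

Measured compounds and their values in this assay:
Compound 1, `C=CCONC(=O)CN1C(=O)S/C(=C\c2ccc(C(=O)N[C@H](C(=O)OC)C(C)C)cc2)C1=O`: > 128000 nM
Compound 2, `COC(=O)[C@@H](NC(=O)c1ccc(/C=C2\SC(=O)N(CC(=O)NOCc3ccccc3)C2=O)cc1)C(C)C`: > 128000 nM
Compound 3, `C=CCONC(=O)Cn1cc(C(=O)NCC(=O)N[C@H](C(=O)O)C(C)C)c2ccccc21`: > 128000 nM

Each of these three values is a limit of the assay and not a number. Compound 1 and compound 2 differ by phenyl in place of vinyl on a saturated chain carbon bound to an oxygen on an unsaturated carbon. In a functional assay on MRC5 cells (Homo sapiens) for inhibition, read by microscopy and resazurin assay, with a stated time of 72 h (on this read-out lower numbers stand for stronger inhibition and higher numbers for weaker inhibition), this change gives a step that the two limits leave unreadable from compound 1 to compound 2, because both values sit at the limit of > 128000 nM in this assay, at which 3 of the 3 values shown sit. Compound 3 has a different core; the difference between the core of compound 3 and the core of compound 1 is not broken down here. For compound 3 only a limit is known in this assay.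

Compound 4, `CC(C)[C@H](NC(=O)CNC(=O)c1cn(CC(=O)NOCc2ccccc2)c2ccccc12)C(=O)O`, has not yet been measured. Among the measured compounds shown here, it differs from compound 3 by phenyl in place of vinyl on a saturated chain carbon bound to an oxygen on an unsaturated carbon, the same change at the same place as the one from compound 1 to compound 2. The expectation for compound 4 rests on compound 3 sitting at the limit of > 128000 nM in this assay, at which 3 of the 3 values shown sit, and on the unreadable step that the two limits leave unreadable from compound 1 to compound 2, so a result at the limit is the likeliest outcome. The expected step is a step that the limit leaves unreadable from compound 3 to compound 4. Compound 4 is estimated at about 200000 nM, with a range from 100000 nM to 600000 nM.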

Compound 4, half-maximal inhibitory concentration: > 128000 nM
Compound 4: only a limit was reported (the forecaster's own chance of this, stated with the estimate: 85%); the middle value lies beyond the limit too.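

Compound 3 and compound 4 both carry a limit and not a number in this assay, so no step can be read between them, because both sit at the same limit: the limit of > 128000 nM in this assay, at which 4 of the 4 values shown sit.

The compounds shown leave open whether the change from allyloxy to benzyloxy, or the difference between the two cores, has any effect on inhibition in this assay.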